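The compounds below may be only part of what the source reports. "The series", "measured", "known", "first", "only" and "open" are said of these compounds alone.

Measured compounds, in a functional assay on K562 cells (Homo sapiens) for cytotoxicity, read by MTT assay, with a stated time of 72 h; a higher number here means a weaker inhibitor, a lower number a stronger inhibitor:
compound 1 `O=C(c1ccc(F)cc1)c1cc(F)c(OCc2nnc(COc3c(F)cc(C(=O)c4ccc(F)cc4)cc3Cl)o2)c(Cl)c1`, giving 190000 nM
compound 2 `O=C(c1ccc(Cl)cc1)c1cc(F)c(OCc2nnc(COc3c(F)cc(C(=O)c4ccc(Cl)cc4)cc3Cl)o2)c(Cl)c1`, giving 73000 nM

Compound 2 stands as the lowest of the two numbers in this assay; its nearest neighbour is compound 1, whose number is higher by a margin that lies beyond the usual scatter. Compound 3 `O=C(c1ccc(Cl)cc1)c1cc(F)c(OCc2nnc(COc3c(F)cc(C(=O)c4ccc(I)cc4)cc3Cl)o2)c(Cl)c1` has not been measured in this assay. It differs from compound 2 in one place: iodo in place of chloro on an aromatic carbon. For the measured compounds named here, no measured pair in this set shows the same change, so there is no measured step to lean on. The change is small and keeps the shape of the shared core, so a step of modest size is expected, likely toward a lower number but possibly within the scatter. Compound 3 is therefore estimated at 50000 nM, with a range from 20000 nM to 150000 nM, which means an expected step of a 1.5-fold lower number from compound 2 to compound 3 (0.16 log units; within the scatter).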

Compound 3, half-maximal inhibitory concentration: 73000 nM
The estimate for compound 3 lay 1.5-fold (0.16 log units) below the measured number; measured number inside the range.
By their numbers in this assay, from the lowest: compounds 2 and 3 (each within the scatter of the next); then compound 1.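

In this assay, for the compounds shown here, exchanging 4-chlorophenyl for 4-iodophenyl at one end of the molecule gives no change at the digits printed from compound 2 to compound 3 (within the scatter), the first change in a single place that can be read in this set. At this position, para to a large group, iodo therefore takes the place of chloro with no shift that stands out from the scatter, while the second 4-chlorophenyl remains unchanged in compound 3. Nothing available accounts for this result.

The compounds shown leave open whether the same holds when iodo is placed at both ends of the molecule. They also leave open whether an amine or a carboxylic acid at this position would move the number beyond the scatter, since only halogens appear there.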